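The compounds below may be only part of what the source reports. "The series", "measured", "known", "first", "only" and "open" are said of these compounds alone.

Measured so far:
- compound 1, `O=C1O[C@@H](CO)CN1c1ccc(-n2cc(-c3ccccn3)cn2)c(F)c1`: > 400 ug/mL
- compound 2, `CCN1CCN(C[C@H]2CN(c3ccc(-n4cc(-c5ccccn5)cn4)c(F)c3)C(=O)O2)CC1`: 99 ug/mL
- compound 3, `O=C1CNC(=O)N1C[C@H]1CN(c2ccc(-n3cc(-c4ccccn4)cn3)c(F)c2)C(=O)O1`: > 400 ug/mL

All three compounds share one core and differ only in the group on a saturated chain carbon bound to a saturated ring carbon. In an ADME assay on HEK293-A cells (Homo sapiens) for cytotoxicity, read by MTT assay, with a stated time of 48 h (on this read-out higher numbers stand for weaker inhibition and lower numbers for stronger inhibition), compound 3 gives only a limit, > 400 ug/mL, and not a number. Compound 1 likewise gives only a limit in this assay, > 400 ug/mL. For the measured compounds named here, compound 2 is the only one with a number, 99 ug/mL in this assay. The measured steps show this: an at least 4.0-fold lower number from compound 1 to compound 2 (0.60 log units; beyond the scatter), and an at least 4.0-fold higher number from compound 2 to compound 3 (0.60 log units; beyond the scatter). The step from compound 1 to compound 3 cannot be read, because both sit at the limit of > 400 ug/mL in this assay, at which 2 of the 3 values shown sit.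

Compound 4, `O=C1O[C@@H](CSc2cccs2)CN1c1ccc(-n2cc(-c3ccccn3)cn2)c(F)c1`, has not been measured. It differs from compound 3 in one place: (thiophen-2-yl)sulfanyl in place of 2,5-dioxoimidazolidin-1-yl on a saturated chain carbon bound to a saturated ring carbon. Going by the values given here, of the measured steps, the one from compound 2 to compound 3 bears on it most, since it also exchanges the whole group at this position, and it was at least modest. The estimate for compound 4 in this assay is therefore a number below the limit, expected as 150 ug/mL (between 40 ug/mL and 400 ug/mL), which would be a step of an at least 2.6-fold lower number from compound 3 to compound 4 (0.42 log units; beyond the scatter). There is a real chance that compound 4 is expected to give only a limit again.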

Compound 4, half-maximal inhibitory concentration: > 400 ug/mL
Compound 4 was reported as a limit; the forecaster's own chance of this, stated with the estimate: 35%; at least 2.6-fold (0.42 log units) between middle value and limit.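

Compound 4 adds a third group on a saturated chain carbon bound to a saturated ring carbon that reads only as a limit in this assay, and it has little in common with 2,5-dioxoimidazolidin-1-yl: (thiophen-2-yl)sulfanyl carries an aromatic ring and 0 hydrogen-bond donors, where the group it replaces carries a non-aromatic ring and 1 hydrogen-bond donor. Exchanging 4-ethylpiperazin-1-yl for (thiophen-2-yl)sulfanyl gives an at least 4.0-fold higher number from compound 2 to compound 4 (0.60 log units; beyond the scatter), so among the four compounds shown the lower number stays with 4-ethylpiperazin-1-yl alone. The steps among compound 1, compound 3 and compound 4 cannot be read, and no order among these three can be given, since each of them is reported only as a limit: the limit of > 400 ug/mL in this assay, at which 3 of the 4 values shown sit.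

As far as these compounds go, what numbers these three compounds would give on a scale without that limit stays open. From the compounds shown here alone, it is also open whether the lower number of compound 2 needs the whole 4-ethylpiperazin-1-yl group, which a piperazine without the ethyl group, a simple dimethylamino group or a carboxylic acid at this position could help to show.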